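Semicarbazones on a shared oxadiazole core: minimum effective dose notes

A few compounds are considered here, and "the series" means these few. Any claim that something is new, unique, unknown or untested is made for them only; others in the source may bear on it.

Measured so far:
compound 1 `CC(C)=CC/C=C(/C)C/C=N/NC(=O)Nc1nnc(-c2ccc([N+](=O)[O-])cc2)o1` gives 300 mg/kg
compound 2 `CC(C)=CC/C=C(/C)C/C=N/NC(=O)Nc1nnc(-c2ccc(C)cc2)o1` gives 300 mg/kg

In a functional assay on the whole organism (strain Swiss albino) with Mus musculus as the target, with a stated time of 4 h (on this read-out lower numbers stand for an effect already at smaller amounts and higher numbers for an effect only at larger amounts of compound), compound 2 stands level with compound 1 at the digits shown. Among the measured compounds shown here, the one step measured on this series, no change at the digits printed from compound 1 to compound 2 (within the scatter), lies within the scatter: changing the group on the aromatic carbon of the terminal phenyl left the dose unmoved.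

Compound 3 `CC(C)=CC/C=C(/C)C/C=N/NC(=O)Nc1nnc(-c2ccc(O)cc2)o1` has not yet been measured. It differs from compound 2 by hydroxy in place of methyl on an aromatic carbon. For the measured compounds named here, the only step that bears on it is the one from compound 1 to compound 2, which also exchanged the group at this same aromatic carbon, para to a large group, without a change beyond the scatter. On that basis no shift beyond the scatter is expected here either, the estimated step being no change at the digits printed from compound 2 to compound 3 (within the scatter). For compound 3 the expected value in this assay is 300 mg/kg, with a range from 150 mg/kg to 600 mg/kg.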

Compound 3, minimum effective dose: 300 mg/kg
Compound 3: the middle estimate sits on the measured number at the digits printed; the measured number falls inside the stated range.
By their numbers in this assay, from the lowest: compounds 1, 2 and 3 (each within the scatter of the next).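

In this assay, hydroxy in place of methyl on the aromatic carbon reads no change at the digits printed from compound 2 to compound 3 (within the scatter) and hydroxy in place of nitro reads no change at the digits printed from compound 1 to compound 3 (within the scatter) at this same position. The position has now carried three groups rather than two, and the added hydroxy brings a hydrogen-bond donor and a hydrogen-bond acceptor that methyl lacks, yet the minimum effective dose does not separate any of the three. Nothing available here accounts for this flat reading.

On these data alone, whether an amine or a carboxylic acid on this aromatic carbon would also read level with these three remains open. Also open, as far as these compounds go, is whether the dose responds to any change elsewhere, such as a longer chain in place of the shared chain, since all three compounds keep that chain and the shared core.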